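This account rests on a few compounds, and the source may have more. Where it says the series, first, only, none or still open, it means among the compounds named here.

Three compounds share one core, a piperazine linked on one side to a sulfonyl group and on the other to an anilide. Compound 1 `O=C(CN1CCN(S(=O)(=O)c2ccccc2F)CC1)Nc1ccccc1F` carries a 2-fluorophenyl on both ends. In an in vitro assay on HEK ts201 cells for negative allosteric modulation of Neuronal acetylcholine receptor; alpha4/beta2 (Homo sapiens), read by fluorescence and calcium flux, with a stated time of 1.5 s (a lower number here means a stronger inhibitor, a higher number a weaker inhibitor), compound 1 gives 8000 nM. Compound 2 `COc1ccc(S(=O)(=O)N2CCN(CC(=O)Nc3ccccc3F)CC2)cc1` differs from compound 1 by 4-methoxyphenyl in place of 2-fluorophenyl on a sulfonyl sulfur; in this assay compound 2 gives 13400 nM, which is a 1.7-fold higher number from compound 1 to compound 2 (0.22 log units; within the scatter). Compound 3 `O=C(CN1CCN(S(=O)(=O)c2ccccc2F)CC1)Nc1ccc(F)cc1` differs from compound 1 at the other end, by 4-fluorophenyl in place of 2-fluorophenyl on an amide-type nitrogen; in this assay compound 3 gives 8000 nM, which is no change at the digits printed from compound 1 to compound 3 (within the scatter).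

Compound 4 `COc1ccc(S(=O)(=O)N2CCN(CC(=O)Nc3ccc(F)cc3)CC2)cc1` has not been measured. It differs from compound 3 by 4-methoxyphenyl in place of 2-fluorophenyl on a sulfonyl sulfur, and the place where this change sits is described in exactly the same words as for the change from compound 1 to compound 2, so the two changes are the same change set on two cores that differ only at the anilide end. Going by the values given here, the single measured instance of this change is small, so a similar step is expected from compound 3 to compound 4, about a 1.7-fold higher number from compound 3 to compound 4 (0.23 log units; within the scatter), because compound 1 to compound 2 gave a 1.7-fold higher number from compound 1 to compound 2 (0.22 log units; within the scatter). For compound 4 the estimated value in this assay is 13500 nM, with a range from 6000 nM to 30000 nM.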

Compound 4, half-maximal inhibitory concentration: 23800 nM
Beside the measured number, compound 4's estimate is 1.8-fold (0.25 log units) below it; measured number inside the range.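

In this assay, 4-methoxyphenyl in place of 2-fluorophenyl on a sulfonyl sulfur gives a 3.0-fold higher number from compound 3 to compound 4 (0.47 log units; beyond the scatter), and this step cannot be told apart from the earlier instance of the same change: the same change on two cores in this assay, a 1.7-fold higher number (0.22 log units; within the scatter) from compound 1 to compound 2 and a 3.0-fold higher number (0.47 log units; beyond the scatter) from compound 3 to compound 4, 1.8-fold (0.25 log units) apart, within the scatter of two such steps. The change at the other end, 4-fluorophenyl in place of 2-fluorophenyl on an amide-type nitrogen, gives a 1.8-fold higher number from compound 2 to compound 4 (0.25 log units; within the scatter), and it also agrees with its earlier instance: the same change on two cores in this assay, no change at the digits printed (within the scatter) from compound 1 to compound 3 and a 1.8-fold higher number (0.25 log units; within the scatter) from compound 2 to compound 4, 1.8-fold (0.25 log units) apart, within the scatter of two such steps. Going by these compounds alone, both changes therefore carry over between the two cores as far as these four compounds can tell, but each comparison rests on only one pair of steps, so this does not show that either change has a fixed size across the series or explain why the numbers move.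

The compounds shown leave open what happens with other groups at either end, such as an unsubstituted phenyl, a pyridine ring or a methyl. Also open, from the compounds shown here alone, is whether these steps hold on a core with a longer chain leading to the amide carbonyl.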